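Fluoro for nitro on the six-membered aromatic ring

The compounds below may be only part of what the source reports. "The series", "measured", "known", "first", "only" and "open" are said of these compounds alone.

Compound 2 `COc1cc(C(=O)c2sc(-c3ccc([N+](=O)[O-])cc3)cc2N)cc(OC)c1OC` carries a nitro group on a six-membered aromatic ring of carbon only. Among the measured compounds shown here, in a functional assay on MOLT-4 cells (Homo sapiens) for antiproliferative activity (on this read-out higher numbers stand for weaker inhibition and lower numbers for stronger inhibition), compound 2 gives 110 nM, the highest of the three numbers measured so far; compound 1 `COc1cc(C(=O)c2sc(-c3ccc(Br)cc3)cc2N)cc(OC)c1OC` lies nearest with 92 nM, and compound 3 `COc1cc(C(=O)c2sc(-c3ccsc3)cc2N)cc(OC)c1OC` furthest with 8.8 nM. The steps between them read a 1.2-fold higher number from compound 1 to compound 2 (0.08 log units; within the scatter), a 10-fold lower number from compound 1 to compound 3 (1.02 log units; beyond the scatter) and a 13-fold lower number from compound 2 to compound 3 (1.10 log units; beyond the scatter).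

Compound 4 `COc1cc(C(=O)c2sc(-c3ccc(F)cc3)cc2N)cc(OC)c1OC` differs from compound 2 by fluoro in place of nitro on an aromatic carbon. For the measured compounds named here, only one measured step bears on this change, the swap of a single group on the same aromatic carbon from compound 1 to compound 2, and it was a 1.2-fold higher number from compound 1 to compound 2 (0.08 log units; within the scatter). The two large steps to compound 3 exchange the whole ring and say nothing about one group on that ring. On this single precedent, no step beyond the scatter is expected in this assay for the fluoro compound. Compound 4 is therefore expected to give 90 nM, with a range from 40 nM to 200 nM. The expected step is a 1.2-fold lower number from compound 2 to compound 4 (0.09 log units; within the scatter).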

Compound 4, half-maximal inhibitory concentration: 12 nM
Compound 4: middle estimate off by 7.5-fold (0.88 log units), on the high side, outside the stated range (below it).
By their numbers in this assay, from the lowest: compounds 3 and 4 (each within the scatter of the next); then compounds 1 and 2 (each within the scatter of the next).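

Swapping one group on this ring can matter after all: in this assay, fluoro stands well apart from both nitro (a 9.2-fold lower number from compound 2 to compound 4 (0.96 log units; beyond the scatter)) and bromo (a 7.7-fold lower number from compound 1 to compound 4 (0.88 log units; beyond the scatter)), so the earlier step within the scatter between bromo and nitro does not hold for every group at this place. The 4-fluorophenyl compound also falls level with the thiophen-3-yl compound (a 1.4-fold higher number from compound 3 to compound 4 (0.13 log units; within the scatter)), so the large gap from compound 3 to compound 1 and compound 2 cannot be read as a matter of ring exchange alone. Nothing available accounts for the separation of fluoro from bromo and nitro.

As far as these compounds go, three groups on an aromatic carbon para to a large group do not set a trend, so it remains open where chloro, methyl, methoxy or an amine would fall. Also open, from the compounds shown here alone, is whether a hydrogen at this place would sit with fluoro or with bromo and nitro.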